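This account rests on a few compounds, and the source may have more. Where it says the series, first, only, none or still open, it means among the compounds named here.

- compound 1 `COc1c(OC)c(OC(=O)C(C)(C)C)c2ccccc2c1OC(=O)C(C)(C)C` gives 5.69 in a physicochemical assay for lipophilicity; a lower number here means a more polar compound, a higher number a more lipophilic compound
- compound 2 `COc1c(OC)c(OC(=O)C(C)(C)C)c2c(Cl)cccc2c1OC(=O)C(C)(C)C` gives 6.1
- compound 3 `CCC(=O)Oc1c(OC(C)C)c(OC(C)C)c(OC(=O)CC)c2cc(Cl)ccc12` gives 5.8

Compound 2 stands within the scatter of compound 3 and clearly above compound 1. Compound 4 `COc1c(OC)c(OC(=O)C(C)(C)C)c2c(C)cccc2c1OC(=O)C(C)(C)C` has methyl in place of chloro on an aromatic carbon and otherwise matches compound 2. Among the compounds with values here, one measured step bears on this: putting chloro in place of hydrogen gave a number 0.41 log units higher from compound 1 to compound 2 (beyond the scatter), a modest change. Within the data shown here, no measured compound carries methyl, so that step serves only as a rough yardstick. Since one group replaces another here, the expected change is smaller than that step, slightly downward or nothing beyond the scatter. In this assay the expected step is a number 0.10 log units lower from compound 2 to compound 4 (within the scatter), a small one. The estimate for compound 4 is 6, with an expected range of 5.7 to 6.3 around it.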

Compound 4, partition coefficient: 6.1
Compound 4: the middle estimate sits 0.10 log units below what was measured, within the range that was stated.
By their numbers in this assay, from the lowest: compounds 1, 3, 2 and 4 (each within the scatter of the next, the first and the last beyond it).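

In this assay, the step of no change at the digits printed from compound 2 to compound 4 (within the scatter) means that chloro and methyl cannot be told apart at this aromatic carbon. The step of a number 0.41 log units higher from compound 1 to compound 4 (beyond the scatter) matches in size the step of a number 0.41 log units higher from compound 1 to compound 2 (beyond the scatter) for chloro, so replacing hydrogen here with either group leaves a compound clearly above compound 1. Within the data shown here, this equal rise is seen only on this shared core, with these two groups.

As far as these compounds go, whether an amine or a carboxylic acid on this same carbon would give a similar number remains open. Nothing measured here accounts for the match between chloro and methyl.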